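From 4-chlorophenyl to 2,4-dichlorophenyl

This account rests on a few compounds, and the source may have more. Where it says the series, first, only, none or still open, it means among the compounds named here.

Compound 1 (`CC(C)=CCOc1ccc2c(c1)OC(c1cccc(Cl)c1)CC2=O`): 6300 nM
Compound 2 (`CC(C)=CCOc1ccc2c(c1)OC(c1ccc(Cl)cc1)CC2=O`): 6970 nM
Compound 3 (`CC(C)=CCOc1ccc2c(c1)OC(c1ccc(Cl)cc1Cl)CC2=O`): not yet measured

In a functional assay (on this read-out lower numbers stand for stronger inhibition and higher numbers for weaker inhibition), the two measured compounds stand level, with compound 2 at 6970 nM and thus within the scatter of compound 1. Going by the values given here, only one measured step connects them, a 1.1-fold higher number from compound 1 to compound 2 (0.04 log units; within the scatter), and it exchanges 3-chlorophenyl for 4-chlorophenyl.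

Compound 3 keeps everything in compound 2 except that 4-chlorophenyl becomes 2,4-dichlorophenyl. This places chloro in place of hydrogen on an aromatic carbon, ortho to a large group and meta to a chloro group (chloro in place of hydrogen on an aromatic carbon). The measured step bears on this change only loosely, since it relocates a single chloro group and does not add a second one. Among the compounds with values here, no measured compound tests a chloro group at this place. With so little evidence, no shift beyond the scatter is expected, and no direction can be firmly argued. The estimated step is a 1.3-fold lower number from compound 2 to compound 3 (0.10 log units; within the scatter) on this reasoning. In this assay compound 3 is expected to read 5500 nM within a range of 2200 nM to 14000 nM for this estimate.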

Compound 3, half-maximal inhibitory concentration: 5260 nM
The estimate for compound 3 lay 1.0-fold (0.02 log units) above the measured number, within the range that was stated.
By their numbers in this assay, from the lowest: compounds 3, 1 and 2 (each within the scatter of the next).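

In this assay, going by these compounds alone, the earlier compounds only relocated a single chloro group, and compound 3 is the first to carry a second one, placed on the aromatic carbon ortho to a large group and meta to a chloro group (a 1.3-fold lower number from compound 2 to compound 3 (0.12 log units; within the scatter)). Set against the 3-chlorophenyl group of compound 1, the 2,4-dichlorophenyl group gives a step that also stays within the scatter (a 1.2-fold lower number from compound 1 to compound 3 (0.08 log units; within the scatter)), so 3-chlorophenyl, 4-chlorophenyl and 2,4-dichlorophenyl all stand level on this read-out, and this position accepts a second chloro group with no step beyond the scatter. Nothing measured alongside these numbers offers an explanation for this result.

The compounds shown leave open whether a group other than chloro at this place, such as a methoxy group, an amine or a carboxylic acid, would give a step beyond the scatter. They also leave open whether the level reading would hold for an unsubstituted phenyl group, which would show whether the chloro groups matter at all on the shared core.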